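Ester side chain of the shared core: cyclopropylmethyl

This account rests on a few compounds, and the source may have more. Where it says the series, first, only, none or still open, it means among the compounds named here.

Within the data shown here, compound 2 `CCCOC(=O)c1ccc2[nH]c(NC(=O)OC)nc2c1` gives 7400 nM in a functional assay on L1210 cells (Mus musculus) for inhibition (on this read-out higher numbers stand for weaker inhibition and lower numbers for stronger inhibition), the higher of the two numbers so far. Compound 1 `COC(=O)Nc1nc2cc(C(=O)OC(C)C)ccc2[nH]1`, the isopropyl ester, gives 700 nM in this assay. Among the measured compounds shown here, the one measured step on this core is an 11-fold higher number from compound 1 to compound 2 (1.02 log units; beyond the scatter), a change in branching at the saturated chain carbon bound to the oxygen next to the carbonyl group. Compound 3 `COC(=O)Nc1nc2cc(C(=O)OCC3CC3)ccc2[nH]1` differs from compound 2 by cyclopropyl in place of ethyl on a saturated chain carbon bound to an oxygen next to a carbonyl group. For the measured compounds named here, that change leaves the carbon bound to the oxygen unbranched and alters only the outer part of the chain, so the measured step speaks to it only indirectly; no measured pair shows what ring closure in the outer chain does here. The expectation for compound 3 is therefore a step from compound 2 of a 1.9-fold lower number from compound 2 to compound 3 (0.27 log units; within the scatter) in this assay, a modest move towards the value of compound 1 at most. Compound 3 is estimated at 4000 nM, with a range of 1000 nM to 15000 nM.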

Compound 3, half-maximal inhibitory concentration: 6900 nM
Estimate against measurement, compound 3: 1.7-fold (0.24 log units) below; the range from low to high includes it.
By their numbers in this assay, from the lowest: compound 1; then compounds 3 and 2 (each within the scatter of the next).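

In this assay, cyclopropyl in place of ethyl on a saturated chain carbon bound to an oxygen next to a carbonyl group gives a 1.1-fold lower number from compound 2 to compound 3 (0.03 log units; within the scatter), so ring closure in the outer part of the chain leaves the read-out where it was. With a 9.9-fold higher number from compound 1 to compound 3 (0.99 log units; beyond the scatter), the cyclopropylmethyl ester stays as far from the isopropyl ester as the propyl ester does, and among these three compounds only compound 1, branched at the carbon bound to the oxygen, stands apart. Nothing available bears on the cause of these steps.

On these data alone, whether the branch at that carbon is what matters remains open, and a cyclopropyl ester or a tert-butyl ester would bear on this. As far as these compounds go, a longer chain, such as butyl, and a carboxylic acid at the same place also remain open.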